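The source may hold more compounds than are shown below. What is called first, only, known or untested is meant among the compounds shown, and "the series" means these compounds.

Series notes. Compound 1 `CN1CCC[C@H]1COc1cccnc1` stands lowest of the three numbers measured in an assay on membranes from brain for displacement of a labelled ligand from Neuronal acetylcholine receptor; alpha4/beta2 (Rattus norvegicus); a lower number here means a stronger inhibitor, a higher number a weaker inhibitor: compound 1 gives 0.15 nM, compound 2 `Cc1ncccc1OC[C@@H]1CCCN1C` gives 22.9 nM, and compound 3 `CN1CCC[C@H]1COc1cccnc1I` gives 606 nM. Both measured changes on the ring carried large penalties: a 150-fold higher number from compound 1 to compound 2 (2.18 log units; beyond the scatter) and a 4000-fold higher number from compound 1 to compound 3 (3.61 log units; beyond the scatter), with a 26-fold higher number from compound 2 to compound 3 (1.42 log units; beyond the scatter) between them. Compound 4 `Cc1ccncc1OC[C@@H]1CCCN1C` takes from compound 1 the change (methyl in place of hydrogen on an aromatic carbon), a methyl on an aromatic carbon opposite the ring nitrogen, so on a different aromatic carbon from the methyl of compound 2. The step from compound 1 to compound 2 bears on it only loosely; a smaller loss than that one is expected, giving a 20-fold higher number from compound 1 to compound 4 (1.30 log units; beyond the scatter). Compound 4 is therefore expected at 3 nM, between 0.4 nM and 30 nM.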

Compound 4, inhibition constant: 4.12 nM
For compound 4 the middle estimate is 1.4-fold (0.14 log units) below the measured one; the measured number falls inside the stated range.
By their numbers in this assay, from the lowest: compound 1; then compound 4; then compound 2; then compound 3.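

In this assay a methyl opposite the ring nitrogen also brings a large loss (a 27-fold higher number from compound 1 to compound 4 (1.44 log units; beyond the scatter)), so the loss is not confined to the aromatic carbon carrying the methyl of compound 2. The same group on the two carbons gives different numbers: compound 4 gives 4.12 nM and compound 2 gives 22.9 nM in the same assay. No supporting data bear on the loss at this position.

Open, on these data alone, is whether fluoro or an amine at this carbon would keep the number closer to that of compound 1. Also open, as far as these compounds go, is how a longer chain such as ethyl would compare with methyl here.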